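This account rests on a few compounds, and the source may have more. Where it says the series, first, only, none or still open, it means among the compounds named here.

Measured so far, in a functional assay on CCRF-CEM cells (Homo sapiens) for cytotoxicity, with a stated time of 72 h; a lower number here means a stronger inhibitor, a higher number a weaker inhibitor:
Compound 1, `CCCCCC#Cc1cn([C@@H]2O[C@H](CO)[C@@H](O)[C@H](O)[C@H]2O)c(=O)nc1N`, gives > 250000 nM, a limit of the assay rather than a number.
Compound 2, `O=c1nc(O)c(C#Cc2ccccc2)cn1[C@@H]1O[C@H](CO)[C@@H](O)[C@H](O)[C@H]1O`, gives 5200 nM.
Compound 3, `Nc1nc(=O)n([C@@H]2O[C@H](CO)[C@@H](O)[C@H](O)[C@H]2O)cc1C#Cc1ccccc1`, gives > 250000 nM, again a limit and not a number.

On these data alone, compound 3 therefore stands at the limit of > 250000 nM in this assay, at which 2 of the 3 values shown sit, and its true value is unknown beyond that. Compound 4, `CCCCCc1ccc(C#Cc2cn([C@@H]3O[C@H](CO)[C@@H](O)[C@H](O)[C@H]3O)c(=O)nc2N)cc1`, differs from it by pentyl in place of hydrogen on an aromatic carbon. The measured steps give little guidance: an at least 48-fold higher number from compound 2 to compound 3 (1.68 log units; beyond the scatter) concerns a different group on the shared core, and a step that the two limits leave unreadable from compound 1 to compound 3 cannot be sized. Within the data shown here, no measured step adds a pentyl to the phenyl ring. The estimate for compound 4 is 200000 nM, with a range from 20000 nM to 1000000 nM, so the expected step is an at least 1.2-fold lower number from compound 3 to compound 4 (0.09 log units; that floor lies within the scatter), most likely another limit.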

Compound 4, half-maximal inhibitory concentration: 115000 nM
The estimate for compound 4 lay 1.7-fold (0.24 log units) above the measured number, within the range that was stated.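

Among these compounds, on the phenyl ring, where the earlier compounds carried only hydrogen, pentyl in place of hydrogen gives the first readable change in this assay among the compounds with the amino group: an at least 2.1-fold lower number from compound 3 to compound 4 (0.33 log units; beyond the scatter). So a substituent at this place, para to a large group, can lower the number rather than leave it at the limit. The step has only a floor, because compound 3 is held at a limit and not a number: the limit of > 250000 nM in this assay, at which 2 of the 4 values shown sit.

On these data alone, whether a shorter chain such as methyl, or an amine or a carboxylic acid, would act like pentyl at this place remains open. So does whether pentyl would lower the number in compound 2, which carries hydroxy instead of amino.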